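Three Compounds at One Level, a Fourth to Follow

A few compounds are considered here, and "the series" means these few. Any claim that something is new, unique, unknown or untested is made for them only; others in the source may bear on it.

In a functional assay on MT4 cells (Homo sapiens) for cytotoxicity (a higher number here means that more compound is tolerated, a lower number that less compound is tolerated), the three measured compounds gave:

compound 1 `CN(C)c1ncnc2c1ncn2[C@@H]1O[C@H](CO[Si](C)(C)C(C)(C)C)[C@@]2(OS(=O)(=O)C=C2N)[C@H]1O[Si](C)(C)C(C)(C)C`: 15000 nM
compound 2 `CNc1ncnc2c1ncn2[C@@H]1O[C@H](CO[Si](C)(C)C(C)(C)C)[C@@]2(OS(=O)(=O)C=C2N)[C@H]1O[Si](C)(C)C(C)(C)C`: 14000 nM
compound 3 `CC(C)(C)[Si](C)(C)OC[C@H]1O[C@@H](n2cnc3ccccc32)[C@H](O[Si](C)(C)C(C)(C)C)[C@]12OS(=O)(=O)C=C2N`: 15000 nM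

Compound 3 stands level with compound 1 at the digits shown, and toward compound 2 there is only a 1.1-fold higher number from compound 2 to compound 3 (0.03 log units; within the scatter) when read from compound 2 to compound 3. The two steps that lead into compound 3, no change at the digits printed from compound 1 to compound 3 (within the scatter) and a 1.1-fold higher number from compound 2 to compound 3 (0.03 log units; within the scatter), both swap the group on the saturated ring carbon of the shared core, and neither moves the number beyond the scatter. Compound 4 `CC(C)(C)[Si](C)(C)OC[C@H]1O[C@@H](n2cnc3ncnc(O)c32)[C@H](O[Si](C)(C)C(C)(C)C)[C@]12OS(=O)(=O)C=C2N` carries a change of the same kind at the same place: a group of 10 heavy atoms (5 carbon, 4 nitrogen, 1 oxygen; one five-membered aromatic ring with 2 hetero atoms, one six-membered aromatic ring with 2 hetero atoms) in place of a group of 9 heavy atoms (7 carbon, 2 nitrogen; one five-membered aromatic ring with 2 hetero atoms, one six-membered aromatic ring of carbon only), on a saturated ring carbon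

in words:

Since the two earlier swaps of the group on that saturated ring carbon left the cytotoxicity unchanged, no step beyond the scatter is expected here either. Compound 4 is therefore expected to give 15000 nM, between 7500 nM and 30000 nM. That estimate means a step of no change at the digits printed from compound 3 to compound 4 (within the scatter).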

Compound 4, half-maximal cytotoxic concentration: 15000 nM
Estimate against measurement, compound 4: no gap at the digits printed; measured number inside the range.
By their numbers in this assay, from the lowest: compounds 2, 1, 3 and 4 (each within the scatter of the next).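

The group on the saturated ring carbon now carries an oxygen, which none of the groups in compounds 1, 2 and 3 does, yet no change at the digits printed from compound 3 to compound 4 (within the scatter) is what this assay records when it replaces the 1H-benzimidazol-1-yl group. Set against the two larger groups, the same holds: a 1.1-fold higher number from compound 2 to compound 4 (0.03 log units; within the scatter) and no change at the digits printed from compound 1 to compound 4 (within the scatter) are the readings. At this position, among these four compounds, no swap moves the number beyond the scatter, and none of the four goes against that. Nothing shown gives a reason for this flat result.

Going by these compounds, whether a carboxylic acid or a simple amine on the six-membered ring would stay level remains open. So does the effect of a free hydroxyl in place of the silyl ethers that all four compounds share.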